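The source may report more compounds than this note shows. Statements on the series, on what has been measured and on what is new or still open speak of the compounds shown alone.

Working notes on the series. Compound 1 `Clc1cncc(OC[C@@H]2CCN2)c1` gives 0.042 nM in an assay on brain for binding affinity to Neuronal acetylcholine receptor; alpha4/beta2 (Rattus norvegicus), read by radioligand binding; a lower number here means a stronger inhibitor, a higher number a weaker inhibitor. Compound 2 `Brc1cncc(OC[C@@H]2CCN2)c1` gives 0.18 nM in this assay, and compound 3 `Cc1cncc(OC[C@@H]2CCN2)c1` gives 0.047 nM. The measured steps are a 4.3-fold higher number from compound 1 to compound 2 (0.63 log units; beyond the scatter), a 1.1-fold higher number from compound 1 to compound 3 (0.05 log units; within the scatter) and a 3.8-fold lower number from compound 2 to compound 3 (0.58 log units; beyond the scatter). On these numbers compound 3 stands second highest of the three: compound 1 lies within the scatter of it, compound 2 lies beyond.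

Compound 4 `CC(=O)NCc1cncc(OC[C@@H]2CCN2)c1` differs from compound 3 by acetamido in place of hydrogen on a saturated chain carbon bound to an aromatic carbon. None of the three measured steps bears directly on this change: each of them swaps one small group for another on an aromatic carbon, and none adds a chain carrying a donor and an acceptor. The series therefore gives no measured guide to the size or direction of this step, and the expectation below rests only on the tight clustering of compound 1 and compound 3 against compound 2, which suggests the core tolerates small changes at this position while a larger change may cost more. For compound 4 the estimate in this assay is 0.3 nM, with a range from 0.05 nM to 2 nM. The expected step of a 6.4-fold higher number from compound 3 to compound 4 (0.81 log units; beyond the scatter) is a modest loss that could still fall within the scatter.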

Compound 4, inhibition constant: 0.54 nM
Beside the measured number, compound 4's estimate is 1.8-fold (0.26 log units) below it; the range from low to high includes it.
By their numbers in this assay, from the lowest: compounds 1 and 3 (each within the scatter of the next); then compound 2; then compound 4.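

Within the data shown here, the acetamido group on the saturated chain carbon is the first change that adds a chain rather than swapping one small group for another, and it gives the largest steps so far: an 11-fold higher number from compound 3 to compound 4 (1.06 log units; beyond the scatter) and a 13-fold higher number from compound 1 to compound 4 (1.11 log units; beyond the scatter). The acetamidomethyl group also sits beyond the scatter of bromo, a 3.0-fold higher number from compound 2 to compound 4 (0.48 log units; beyond the scatter), so this position separates the chain from all three small groups, yet in this assay compound 4 still gives 0.54 nM, which shows that a chain with a hydrogen-bond donor and acceptor is accepted here at a measurable cost. No measurement shown bears on the cause of this loss.

With a single chain-bearing compound, the series cannot separate the effect of the carbonyl and amide hydrogen from that of the added chain as a whole. An aminomethyl or hydroxymethyl group, a carboxylic acid or a longer chain such as acetamidoethyl would be needed to show whether the loss follows the amide itself, the chain length or neither.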